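This account rests on a few compounds, and the source may have more. Where it says the series, first, only, none or still open, it means among the compounds named here.

Measured compounds:
- compound 1 `CCCCCCNc1nc(SCc2ccc(C(F)(F)F)cc2)nc2ccccc12` gives 24300 nM in a functional assay on MCF7 cells (Homo sapiens) for cytotoxicity, read by MTT assay, with a stated time of 72 h; a lower number here means a stronger inhibitor, a higher number a weaker inhibitor
- compound 2 `FC(F)(F)c1ccc(CSc2nc(N3CCCCC3)c3ccccc3n2)cc1` gives > 50000 nM, which is a limit of the assay and not a number
- compound 3 `FC(F)(F)c1ccc(CSc2nc(Nc3cccc(Br)c3)c3ccccc3n2)cc1` gives 25600 nM

Of the two numbers that are not limits, compound 1 holds the lowest, and its nearest neighbour, compound 3, sits within the usual scatter of it. The result for compound 2 is a limit of the assay; the change to piperidin-1-yl on the aromatic carbon gave an at least 2.0-fold higher number from compound 1 to compound 2 (0.31 log units; beyond the scatter). Compound 4 `O=[N+]([O-])c1ccc(Nc2nc(SCc3ccc(C(F)(F)F)cc3)nc3ccccc23)cc1` has not been measured yet. It differs from compound 1 by 4-nitrophenyl in place of hexyl on a nitrogen on an aromatic ring. The step that bears most directly on this change is the one in which a 3-bromophenyl replaced hexyl on the same nitrogen: it gave a 1.1-fold higher number from compound 1 to compound 3 (0.02 log units; within the scatter). Since that swap of an aromatic ring for the hexyl chain left the number essentially unchanged, no step beyond the scatter is expected here, a 1.0-fold higher number from compound 1 to compound 4 (0.01 log units; within the scatter). Compound 4 is therefore estimated to give 25000 nM, with a likely range from 10000 nM to 60000 nM.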

Compound 4, half-maximal inhibitory concentration: 17900 nM
Compound 4: middle estimate off by 1.4-fold (0.15 log units), on the high side; the range from low to high includes it.
By their numbers in this assay, from the lowest: compounds 4, 1 and 3 (each within the scatter of the next). At a limit, above all of these: compound 2.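

In this assay the change gives a 1.4-fold lower number from compound 1 to compound 4 (0.13 log units; within the scatter) and a 1.4-fold lower number from compound 3 to compound 4 (0.16 log units; within the scatter) as well, so a second aromatic ring on this nitrogen, now with a different substituent, again cannot be told apart from the hexyl chain. Compound 2 stands at a limit of the assay and not at a number: the limit of > 50000 nM in this assay, at which 1 of the 4 values shown sits. Even so, the change to (4-nitrophenyl)amino gives an at least 2.7-fold lower number from compound 2 to compound 4 (0.44 log units; beyond the scatter) and so, unlike the step from compound 2 to compound 3, whose floor lies within the scatter, clearly separates an amino-linked group from piperidin-1-yl.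

Still open, as far as these compounds go, is whether any group on this nitrogen moves the number beyond the scatter, such as a phenyl ring carrying an amine or a carboxylic acid, or a chain shorter than hexyl. Whether the aromatic ring offers any real advantage over the hexyl chain also remains unsettled.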